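From formyl to a silicon-bearing group on the ring

The compounds below may be only part of what the source reports. "The series", "measured", "known", "first", "only" and "open" are said of these compounds alone.

Of the compounds shown here, three built on a shared core have been tested in a functional assay on MCF7 cells (Homo sapiens) for antiproliferative activity, read by MTT assay, with a stated time of 48 h; a lower number here means a stronger inhibitor, a higher number a weaker inhibitor. In that test, compound 1 (`CO[C@]1(C)/C=C/C(=O)/C(CO)=C\C[C@](C)(CCC=C(C)C)/C=C/[C@H]1OC(=O)C=C(C)C`) gives 14300 nM, compound 2 (`C=C1/C=C/C(=O)/C(CO)=C\C[C@](C)(CCC=C(C)C)/C=C/[C@H]1OC(=O)C=C(C)C`) gives 2750 nM and compound 3 (`CC(C)=CCC[C@]1(C)/C=C/[C@@H](OC(=O)C=C(C)C)[C@](C)(O)/C=C/C(=O)/C(C=O)=C\C1`) gives 12600 nM. Compound 3 therefore holds the second highest of the three numbers. It lies within the usual scatter of compound 1, so those two cannot be told apart, while compound 2 has a lower number by more than the scatter.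

Compound 4 (`CC[Si](CC)(CC)C/C1=C/C[C@](C)(CCC=C(C)C)/C=C/[C@@H](OC(=O)C=C(C)C)[C@](C)(O)/C=C/C1=O`) has not yet been measured. It differs from compound 3 in one place: a group of 8 heavy atoms (7 carbon, 1 silicon; no ring) in place of a group of 2 heavy atoms (1 carbon, 1 oxygen; no ring), on a double-bonded ring carbon. The formyl group leaves a double-bonded ring carbon, and a group with no common name enters there.

For the measured compounds named here, no two tested compounds differ in just one place, so the data show no direct precedent for this swap. A modest move toward a higher number, meaning a weaker inhibitor, is expected, and it may not exceed the scatter. The estimated step is a 1.3-fold higher number from compound 3 to compound 4 (0.13 log units; within the scatter). For compound 4 the estimated value is 17000 nM, with an expected range of 6000 nM to 50000 nM.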

Compound 4, half-maximal inhibitory concentration: 3150 nM
Beside the measured number, compound 4's estimate is 5.4-fold (0.73 log units) above it; measured number below the stated range.
By their numbers in this assay, from the lowest: compounds 2 and 4 (each within the scatter of the next); then compounds 3 and 1 (each within the scatter of the next).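

For the compounds shown here, this swap gives the first direct one-place comparison: in this assay, replacing the formyl group on the double-bonded ring carbon gives a 4.0-fold lower number from compound 3 to compound 4 (0.60 log units; beyond the scatter). The entering group has 8 heavy atoms and 0 hydrogen-bond acceptors, while the formyl group has 2 heavy atoms and 1 hydrogen-bond acceptor, so at this position on the core of compound 3, the formyl group is not required for a stronger result, and a much larger group containing silicon is compatible with it. No measurement shown here explains the step.

A single swap cannot show whether the silicon atom matters or whether the carbon chains attached to it would give the same result, so an all-carbon counterpart would be the informative comparison, and a carboxylic acid or an amine at the same ring carbon would test quite different groups. From the compounds shown here alone, it also remains open whether the same swap would lower the number on the core of compound 2, which carries a different group at this ring carbon and differs elsewhere too.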